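Aminocarbonylurea thiophene amides: para substituent on the aryl ring

A few compounds are considered here, and "the series" means these few. Any claim that something is new, unique, unknown or untested is made for them only; others in the source may bear on it.

Within the data shown here, compound 1 `NC(=O)Nc1sc(-c2ccc(C(=O)N3CCCCC3)cc2)cc1C(=O)N[C@H]1CCCNC1` is the only member of the series with a number in a functional assay on HT-29 cells (Homo sapiens); on this read-out lower numbers stand for an effect already at smaller amounts and higher numbers for an effect only at larger amounts of compound; in this assay compound 1 gives 130 nM. Compound 2 `CNC(=O)c1cc(-c2ccccc2)sc1NC(N)=O` belongs to the same set, but for compound 2 the entry in this assay is "not determined" (no result reported), so nothing can be drawn from it. Among the measured compounds shown here, no step between two measured compounds is available, and no structure–activity pattern can be stated from one number.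

Compound 3 `Cc1ccc(-c2cc(C(=O)N[C@H]3CCCNC3)c(NC(N)=O)s2)cc1` differs from compound 1 in one place: methyl in place of (piperidin-1-yl)carbonyl on an aromatic carbon. For the measured compounds named here, with no precedent for this kind of change, the expectation rests on the single value of compound 1 and on the size of the group that leaves. A moderate step towards an effect only at larger amounts is expected, possibly beyond the scatter, as a 2.7-fold higher number from compound 1 to compound 3 (0.43 log units; beyond the scatter). Compound 3 is thus estimated at 350 nM in this assay, within a range from 90 nM to 1500 nM.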

Compound 3, half-maximal effective concentration: 70 nM
Beside the measured number, compound 3's estimate is 5.0-fold (0.70 log units) above it; the whole stated range lies above it.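

In this assay, methyl in place of (piperidin-1-yl)carbonyl on an aromatic carbon gives a 1.9-fold lower number from compound 1 to compound 3 (0.27 log units; within the scatter) and so does not separate the two compounds on this read-out. Among these compounds, this is the first reading at this position, and it shows that the whole (piperidin-1-yl)carbonyl group, including its six-membered ring and carbonyl, can be exchanged for methyl with a difference that stays within the scatter. No supporting data are available to explain this result.

The compounds with numbers carry only these two groups at this place, leaving open how an amine, a carboxylic acid or a longer alkyl chain would read there. From the compounds shown here alone, whether the same exchange gives a similar result with a different amide on the shared core also remains open.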